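Adding one methyl to compound 3

The compounds below may be only part of what the source reports. "The series", "measured", "known", "first", "only" and "open" are said of these compounds alone.

compound 1 `O=C1OC[C@H](Cc2ccccc2F)[C@H]1Cc1ccc(Cl)c(Cl)c1` gives 28000 nM
compound 2 `COc1ccc(C[C@H]2COC(=O)[C@@H]2Cc2ccc(Cl)c(Cl)c2)cc1` gives 37000 nM
compound 3 `Cc1ccc(C[C@H]2COC(=O)[C@@H]2Cc2ccc(Cl)c(Cl)c2)cc1` gives 19000 nM

All three values come from a functional assay on HL-60 cells (Homo sapiens) for cytotoxicity, read by WST assay, with a stated time of 48 h (on this read-out lower numbers stand for an effect already at smaller amounts and higher numbers for an effect only at larger amounts of compound), and lie within the scatter of one another, so compound 3 stands level with compound 1 and compound 2. Compound 4 `Cc1ccc(C[C@H]2COC(=O)[C@@H]2Cc2ccc(Cl)c(Cl)c2)cc1C` differs from compound 3 in one place (methyl in place of hydrogen on an aromatic carbon) with methyl in place of hydrogen on an aromatic carbon, turning 4-methylphenyl into 3,4-dimethylphenyl. The three measured steps all change this same aromatic group (a 1.3-fold higher number from compound 1 to compound 2 (0.12 log units; within the scatter)), (a 1.5-fold lower number from compound 1 to compound 3 (0.17 log units; within the scatter)), (a 1.9-fold lower number from compound 2 to compound 3 (0.29 log units; within the scatter)) and each stayed within the scatter. No step beyond the scatter is therefore expected in this assay here. The expected change is small (a 1.1-fold lower number from compound 3 to compound 4 (0.05 log units; within the scatter)) and would lie within the scatter. Compound 4 is estimated at 17000 nM with an expected range from 8000 nM to 36000 nM in this measurement.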

Compound 4, half-maximal effective concentration: 16000 nM
Beside the measured number, compound 4's estimate is 1.1-fold (0.03 log units) above it; low and high end bracket the measured number.
By their numbers in this assay, from the lowest: compounds 4, 3, 1 and 2 (each within the scatter of the next, the first and the last beyond it).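

In this assay, a methyl ortho to a methyl group on the aromatic ring changes little (a 1.2-fold lower number from compound 3 to compound 4 (0.07 log units; within the scatter)), so turning 4-methylphenyl into 3,4-dimethylphenyl gives no clear shift. Set against 4-methoxyphenyl, 3,4-dimethylphenyl gives the only step beyond the scatter so far, a modest one (a 2.3-fold lower number from compound 2 to compound 4 (0.36 log units; beyond the scatter)), while against 2-fluorophenyl it stays within the scatter (a 1.8-fold lower number from compound 1 to compound 4 (0.24 log units; within the scatter)). Nothing available explains these differences.

Still open, on these data alone, is whether an ethyl, an amine or a carboxylic acid at this position would move the number further.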